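From propanoylamino to methylamino on a shared core

The source may hold more compounds than are shown below. What is called first, only, known or untested is meant among the compounds shown, and "the series" means these compounds.

In an ADME assay on MT4 cells (Homo sapiens) for cytotoxicity, read by MTT assay, with a stated time of 4 days (a higher number here means that more compound is tolerated, a lower number that less compound is tolerated), compound 2 `CCC(=O)Nc1c(C)c(C(OC(C)(C)C)C(=O)O)c(-c2ccc(C)c(C)c2)c(C)c1-c1ccc(C)c(C)c1` gives 15000 nM as its half-maximal cytotoxic concentration. Compound 3 `Cc1ccc(-c2c(C)c(-c3ccc(Cl)c(F)c3)c(C(OC(C)(C)C)C(=O)O)c(C)c2NS(C)(=O)=O)cc1C` gives 22000 nM and stands within the scatter of compound 2. Going by the values given here, compound 1 `Cc1ccc(-c2c(C)c(-c3ccc4c(c3)CCO4)c(C(OC(C)(C)C)C(=O)O)c(C)c2NS(C)(=O)=O)cc1C` gives 38000 nM and is the only compound whose gap to compound 2 goes beyond the scatter.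

Compound 4 `CNc1c(C)c(C(OC(C)(C)C)C(=O)O)c(-c2ccc(C)c(C)c2)c(C)c1-c1ccc(C)c(C)c1` differs from compound 2 in one place. The change is methyl in place of propanoyl on a nitrogen on an aromatic ring and amounts to methyl in place of propanoyl on a nitrogen on an aromatic ring. Among the compounds with values here, no measured step isolates a change on this nitrogen. Within the data shown here, the one step available, a 1.7-fold lower number from compound 1 to compound 3 (0.24 log units; within the scatter), exchanges a different group on an aromatic carbon and stays within the scatter, so it bears on the new change only indirectly. With so little evidence, no step beyond the scatter is expected in this assay and no direction can be argued with confidence. The expectation therefore stays anchored on compound 2 at 15000 nM and allows a wide margin on either side. The estimated change is small, with a 1.1-fold lower number from compound 2 to compound 4 (0.03 log units; within the scatter) as the expected step. Compound 4 is expected at 14000 nM with an estimated range from 6000 nM to 33000 nM for the measurement still to come.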

Compound 4, half-maximal cytotoxic concentration: 8800 nM
For compound 4 the middle estimate is 1.6-fold (0.20 log units) above the measured one; measured number inside the range.
By their numbers in this assay, from the lowest: compounds 4, 2, 3 and 1 (each within the scatter of the next, the first and the last beyond it).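

In this assay, the first step measured on this nitrogen, a 1.7-fold lower number from compound 2 to compound 4 (0.23 log units; within the scatter), shows that methyl in place of propanoyl on a nitrogen on an aromatic ring does not separate the two compounds beyond the usual scatter of repeated measurements. The exchange goes from propanoyl, with its carbonyl, to methyl, and so far a change of that extent at this position leaves the two compounds indistinguishable in this assay, something the earlier step, made on an aromatic carbon, could not show. No measurement is available here that would explain this result.

The compounds shown leave open whether the unsubstituted amine, or a longer chain such as butanoyl on the same nitrogen, would also stay within the scatter of compound 2. Going by these compounds alone, with only a single step at this position, they also leave open whether the same exchange would read alike alongside the other aromatic groups carried by compound 1 and compound 3.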